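The source may hold more compounds than are shown below. What is called first, only, known or untested is meant among the compounds shown, and "the series" means these compounds.

Measured so far in a functional assay on MCF7 cells (Homo sapiens) for inhibition, read by MTT assay, with a stated time of 24 h; a higher number here means a weaker inhibitor, a lower number a stronger inhibitor:
- compound 1, `CCCCCCCCn1cc(COC2(C(F)(F)F)Oc3ccccc3C=C2C(=O)OCC)nn1`: > 150000 nM
- compound 2, `CCOC(=O)C1=Cc2ccccc2OC1(OCc1cc(-c2ccc([N+](=O)[O-])cc2)no1)C(F)(F)F`: > 150000 nM

In this assay compound 1 gives > 150000 nM, which is a limit of the assay and not a number. In this assay compound 2 gives > 150000 nM, again a limit rather than a number. Compound 1 therefore stands at the edge of what the assay reports, and it shares that position with the only other compound shown: the limit of > 150000 nM in this assay, at which 2 of the 2 values shown sit. Among the measured compounds shown here, no step between two measured compounds is available, so nothing yet shows a change that the assay can resolve.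

Compound 3, `CCOC(=O)C1=Cc2ccccc2OC1(OCc1cn(CC(=O)Nc2ccc(I)cc2Cl)nn1)C(F)(F)F`, differs from compound 1 in one place: (2-chloro-4-iodophenyl)carbamoyl in place of heptyl on a saturated chain carbon bound to an aromatic nitrogen. With both shown values sitting at the limit, the expected step in this assay is a step that the limit leaves unreadable from compound 1 to compound 3, that is, none beyond the scatter, and the most probable outcome is that the assay again reports only a limit. Compound 3 is estimated at 200000 nM, with a range of 50000 nM to 800000 nM.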

Compound 3, half-maximal inhibitory concentration: 28100 nM
Compound 3: the middle estimate sits 7.1-fold (0.85 log units) above what was measured; measured number outside the range, below it.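

In this assay, (2-chloro-4-iodophenyl)carbamoyl in place of heptyl on a saturated chain carbon bound to an aromatic nitrogen gives an at least 5.3-fold lower number from compound 1 to compound 3 (0.72 log units; beyond the scatter). This position can therefore change the read-out, and compound 3, at 28100 nM, is the only compound shown with a number rather than a limit. The true size of the step stays undefined because compound 1 gives only a limit: the limit of > 150000 nM in this assay, at which 2 of the 3 values shown sit.

The change brings in an aromatic ring, a carbonyl, an amide hydrogen, chlorine and iodine together, and the compounds shown do not separate their contributions. Open too, going by these compounds, is whether a simple phenylcarbamoyl without chlorine or iodine, or a carboxylic acid or an amine at the same place, would also give a number rather than a limit.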